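The source may hold more compounds than are shown below. What is called first, only, known or untested is meant among the compounds shown, and "the series" means these compounds.

Of the compounds shown here, three built on one shared core have been tested in a functional assay on SF-268 cells (Homo sapiens) for antiproliferative activity, read by MTT assay, with a stated time of 96 h; a higher number here means a weaker inhibitor, a lower number a stronger inhibitor. Compound 1 `CN(C)c1ccc(N2C(=O)NC3(CSC4=C3C(=O)c3ncccc3C4=O)C2=O)cc1` gives 950 nM. Compound 2 `O=C1NC(=O)C2(CSC3=C2C(=O)c2ncccc2C3=O)N1`, in which hydrogen replaces the 4-(dimethylamino)phenyl group on an amide-type nitrogen in a ring, gives 3100 nM, and the step of a 3.3-fold higher number from compound 1 to compound 2 (0.51 log units; beyond the scatter) shows that taking away that aryl group weakens the compound modestly. Compound 3 `CCN(CC)c1ccc(N2C(=O)NC3(CSC4=C3C(=O)c3ncccc3C4=O)C2=O)cc1` gives 960 nM; the step of a 1.0-fold higher number from compound 1 to compound 3 (0.00 log units; within the scatter) shows that exchanging dimethylamino for diethylamino makes no difference. Among the three, compound 3 therefore sits together with compound 1 and well apart from compound 2.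

Compound 4 `CCCCc1ccc(N2C(=O)NC3(CSC4=C3C(=O)c3ncccc3C4=O)C2=O)cc1` has not yet been measured. It differs from compound 3 by butyl in place of diethylamino on an aromatic carbon. The aryl group itself remains, so the modest loss seen in a 3.3-fold higher number from compound 1 to compound 2 (0.51 log units; beyond the scatter) need not recur, and a 1.0-fold higher number from compound 1 to compound 3 (0.00 log units; within the scatter) shows that the group on that aromatic carbon can be altered without effect. A step no larger than the scatter is expected, in either direction. Compound 4 is estimated at 1200 nM, within a range of 500 nM to 3000 nM. This amounts to an expected step of a 1.3-fold higher number from compound 3 to compound 4 (0.10 log units; within the scatter).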

Compound 4, half-maximal inhibitory concentration: 400 nM
Compound 4: the middle estimate sits 3.0-fold (0.48 log units) above what was measured; measured number below the stated range.
By their numbers in this assay, from the lowest: compound 4; then compounds 1 and 3 (each within the scatter of the next); then compound 2.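

The group on that aromatic carbon is less free to change than compound 1 and compound 3 suggested: in this assay, diethylamino and dimethylamino match each other, yet butyl gives a 2.4-fold lower number from compound 3 to compound 4 (0.38 log units; beyond the scatter) and also a 2.4-fold lower number from compound 1 to compound 4 (0.38 log units; beyond the scatter). With butyl on the aryl group, the gain over the hydrogen-bearing nitrogen reaches a 7.8-fold lower number from compound 2 to compound 4 (0.89 log units; beyond the scatter), the widest step among these compounds, so what the aryl group adds depends on what it carries. Nothing measured here accounts for the difference between butyl and the two amino groups.

Butyl is the only carbon chain shown, so it remains open whether a shorter chain such as ethyl, a longer chain such as hexyl, or a ring such as cyclohexyl would keep, lose or extend this step. From the compounds shown here alone, how an oxygen-linked group such as butoxy would compare on that same aromatic carbon is equally open.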